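The source may hold more compounds than are shown below. What is called first, only, known or untested is meant among the compounds shown, and "the series" means these compounds.

Measured compounds:
- compound 1, `CCCCCCc1nc(C(F)(F)F)ccc1CNC(=O)C(C)c1ccc(NS(C)(=O)=O)c(F)c1`: 1.6 nM
- compound 2, `CC(C(=O)NCc1ccc(C(F)(F)F)nc1C1=C[C@H](C)CCC1)c1ccc(NS(C)(=O)=O)c(F)c1`: 0.1 nM
- compound 3, `CC(C)=Cc1nc(C(F)(F)F)ccc1CNC(=O)C(C)c1ccc(NS(C)(=O)=O)c(F)c1`: 11.5 nM

All three share one core and differ only in the group on the aromatic carbon. In an assay on CHO cells for antagonist activity at transient receptor potential cation channel subfamily V member 1 (Homo sapiens), read by FLIPR and calcium flux (on this read-out lower numbers stand for stronger inhibition and higher numbers for weaker inhibition), compound 3 gives 11.5 nM, the highest number of the three: against compound 1 the step is a 7.2-fold higher number from compound 1 to compound 3 (0.86 log units; beyond the scatter), and against compound 2 it is a 120-fold higher number from compound 2 to compound 3 (2.06 log units; beyond the scatter).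

Compound 4, `CCC/C=C/c1nc(C(F)(F)F)ccc1CNC(=O)C(C)c1ccc(NS(C)(=O)=O)c(F)c1`, carries the change (pent-1-en-1-yl in place of 2-methylprop-1-en-1-yl on an aromatic carbon). The step that bears on it most is a 7.2-fold higher number from compound 1 to compound 3 (0.86 log units; beyond the scatter), where a hexyl chain was replaced by the shorter branched alkenyl and the number rose; compound 4 restores a longer unbranched chain while keeping the double bond. The step of a 120-fold higher number from compound 2 to compound 3 (2.06 log units; beyond the scatter) involves a ring and bears less on this change. A modest move back toward the number of compound 1 is therefore expected, i.e. a 3.3-fold lower number from compound 3 to compound 4 (0.52 log units; beyond the scatter).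

Compound 4 is estimated at 3.5 nM in this assay, with a range of 1 nM to 12 nM.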

Compound 4, inhibition constant: 0.9 nM
Compound 4: middle estimate off by 3.9-fold (0.59 log units), on the high side; the whole stated range lies above it.
By their numbers in this assay, from the lowest: compound 2; then compounds 4 and 1 (each within the scatter of the next); then compound 3.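

In this assay, the unbranched pent-1-en-1-yl group in place of 2-methylprop-1-en-1-yl gives a large drop (a 13-fold lower number from compound 3 to compound 4 (1.11 log units; beyond the scatter)), so an alkenyl group at this position can reach the level of the saturated hexyl chain (a 1.8-fold lower number from compound 1 to compound 4 (0.25 log units; within the scatter)). The 3-methylcyclohex-1-en-1-yl group remains clearly ahead of this open chain (a 9.0-fold higher number from compound 2 to compound 4 (0.95 log units; beyond the scatter)), giving the lowest number among the four compounds. No measurement shown here accounts for these differences.

The change from 2-methylprop-1-en-1-yl to pent-1-en-1-yl alters both chain length and branching, so the two contributions remain inseparable. Also open, going by these compounds, are whether a cyclohexyl group would match the 3-methylcyclohex-1-en-1-yl group and whether an unsubstituted cyclohex-1-en-1-yl group would retain its low number.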